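Moving the Chlorine on a Shared Core

The compounds below may be only part of what the source reports. "The series", "measured", "known", "first", "only" and "open" are said of these compounds alone.

Going by the values given here, compound 3 `Oc1ccc(-c2cc(-c3ccc(Cl)cc3)nc(-c3ccco3)c2)cc1` gives 7280 nM in a functional assay on DU-145 cells (Homo sapiens) for cytotoxicity, read by CCK-8 assay and cell counting, with a stated time of 2 days (on this read-out higher numbers stand for weaker inhibition and lower numbers for stronger inhibition), the highest of the three numbers so far, though its gaps to compound 2 `Oc1ccc(-c2cc(-c3ccsc3)nc(-c3cccc(Cl)c3)c2)cc1` at 6220 nM and to compound 1 `Oc1ccc(-c2cc(-c3cccc(Cl)c3)nc(-c3cccs3)c2)cc1` at 5740 nM both lie within the scatter. Compound 4 `Oc1ccc(-c2cc(-c3cccc(Cl)c3)nc(-c3ccco3)c2)cc1` differs from compound 3 by 3-chlorophenyl in place of 4-chlorophenyl on an aromatic carbon. Among the compounds with values here, the only measured step between two compounds differing in one place, a 1.1-fold higher number from compound 1 to compound 2 (0.03 log units; within the scatter), concerns the thiophene ring and not the chlorine, so no pair isolates the present change. With nothing pointing to a shift, compound 4 is expected to move only within the scatter, an expected step of a 1.1-fold lower number from compound 3 to compound 4 (0.05 log units; within the scatter). Compound 4 is therefore estimated at 6500 nM, with a range from 3300 nM to 13000 nM.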

Compound 4, half-maximal inhibitory concentration: 5750 nM
Beside the measured number, compound 4's estimate is 1.1-fold (0.05 log units) above it, and the stated range covers the measured number.
By their numbers in this assay, from the lowest: compounds 1, 4, 2 and 3 (each within the scatter of the next).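

Swapping 4-chlorophenyl for 3-chlorophenyl gives a 1.3-fold lower number from compound 3 to compound 4 (0.10 log units; within the scatter), so in this assay the chlorine can sit at either ring position without a readable change. Furan-2-yl likewise reads the same as both thiophene groups, with a 1.1-fold lower number from compound 2 to compound 4 (0.03 log units; within the scatter) and a 1.0-fold higher number from compound 1 to compound 4 (0.00 log units; within the scatter). Nothing available explains why these steps are so small.

Going by these compounds, what remains open is whether an amine or a carboxylic acid in place of the chlorine would move the number beyond the scatter. The compounds shown also leave open what a methoxy group in place of the hydroxyl of the 4-hydroxyphenyl group would do.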